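From 3-methylphenyl to tert-butyl in a small series

This account rests on a few compounds, and the source may have more. Where it says the series, first, only, none or still open, it means among the compounds named here.

In an ADME assay on Caco-2 cells (Homo sapiens) for permeability, read by LC-MS, in the apical to basolateral direction, with a stated time of 60 min, at pH 6.5 (a higher number here means that the compound crosses the layer faster, a lower number that the compound crosses the layer more slowly), compound 1 (`Cc1cccc([C@@H](O)C(=O)N2N=CC[C@H]2C(=O)NCc2cc(Cl)ccc2-n2cnnn2)c1`) gives 9.7 10^-6 cm/s and stands among the two higher numbers of the three measured. Compound 3 (`CC(C)(C)C[C@@H](O)C(=O)N1CC[C@@H]2C[C@@]21C(=O)NCc1cc(Cl)ccc1-n1cnnn1`) gives 7.8 10^-6 cm/s in this assay, within the scatter of compound 1. Compound 2 (`O=C(NCc1cc(Cl)ccc1-n1cnnn1)[C@@H]1[C@@H]2C[C@@H]2CN1C(=O)[C@H](O)Cc1ccccn1`) gives 0.62 10^-6 cm/s in this assay, a number beyond the scatter from that of compound 1.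

Compound 4 (`CC(C)(C)[C@@H](O)C(=O)N1N=CC[C@H]1C(=O)NCc1cc(Cl)ccc1-n1cnnn1`) keeps the core of compound 1 and changes one group: tert-butyl in place of 3-methylphenyl on a saturated chain carbon bound to a carbonyl carbon and an oxygen on a saturated carbon. Among the compounds with values here, no measured pair shows this change alone, so any step is only an expectation. The closest guide is compound 3, which reaches 7.8 10^-6 cm/s with a ring-free carbon group on a core of its own. The expected step of a 1.4-fold lower number from compound 1 to compound 4 (0.14 log units; within the scatter) is therefore estimated to stay within the scatter. For compound 4 the estimated value is 7 10^-6 cm/s in this assay, with 2.5 10^-6 cm/s to 16 10^-6 cm/s as the expected range.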

Compound 4, apparent permeability: 15 10^-6 cm/s
Compound 4: the middle estimate sits 2.1-fold (0.33 log units) below what was measured; the range from low to high includes it.
By their numbers in this assay, from the lowest: compound 2; then compounds 3, 1 and 4 (each within the scatter of the next).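

In this assay, within the data shown here, compounds 1 and 4 form the first pair that differs in one place, and the step is a 1.5-fold higher number from compound 1 to compound 4 (0.19 log units; within the scatter), which lies within the scatter. On this shared core, therefore, tert-butyl can stand in place of 3-methylphenyl on a saturated chain carbon bound to a carbonyl carbon and an oxygen on a saturated carbon without a step beyond the scatter, so the six-membered aromatic ring of carbon only is not needed here to keep the number in this range. Nothing measured here gives a reason for this result.

On these data alone, whether an amine, a carboxylic acid or a longer chain at this position would also stay within the scatter of compound 1 remains open. Also open, as far as these compounds go, is what sets compound 2 apart at 0.62 10^-6 cm/s, since it differs from the others in more than one place.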